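The source may hold more compounds than are shown below. What is called first, only, known or untested is meant among the compounds shown, and "the series" means these compounds.

Compound 2 `Cc1cccc(NC(=O)CN2CCC(c3ccccc3)CC2)c1` and compound 1 `Cc1cccc(NC(=O)CN2CCC(c3ccc(Cl)cc3)CC2)c1` share one core and differ only at an aromatic carbon. In an assay on HEK293 cells for displacement of a labelled ligand from D(4) dopamine receptor (Homo sapiens), read by scintillation counting, with a stated time of 60 min (a higher number here means a weaker inhibitor, a lower number a stronger inhibitor), compound 1 gives 115 nM, while compound 2 gives 25.8 nM. The step of a 4.5-fold lower number from compound 1 to compound 2 (0.65 log units; beyond the scatter) is the only one measured so far, and it leaves compound 2 with the lower of the two numbers.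

Compound 3 `Cc1ccc(C2CCN(CC(=O)Nc3cccc(C)c3)CC2)cc1` is the next step from compound 2: methyl in place of hydrogen on an aromatic carbon. The change sits on the same ring, para to a large group, where compound 1 carries its chloro, so the step of a 4.5-fold lower number from compound 1 to compound 2 (0.65 log units; beyond the scatter) bears on it directly: placing a group at this carbon was met with a higher number, beyond the scatter. A methyl is not a chloro, so the size is uncertain, but a modest rise in this assay is expected, with a 2.3-fold higher number from compound 2 to compound 3 (0.37 log units; beyond the scatter). Compound 3 is therefore estimated at 60 nM, within 25 nM to 150 nM.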

Compound 3, inhibition constant: 110 nM
Compound 3: the middle estimate sits 1.8-fold (0.26 log units) below what was measured; low and high end bracket the measured number.
By their numbers in this assay, from the lowest: compound 2; then compounds 3 and 1 (each within the scatter of the next).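

In this assay, methyl at this carbon gives a 4.3-fold higher number from compound 2 to compound 3 (0.63 log units; beyond the scatter), so the rise seen with chloro is not particular to that group. The two groups cannot be told apart here, with a 1.0-fold lower number from compound 1 to compound 3 (0.02 log units; within the scatter), and among the compounds shown, both substituents on this aromatic carbon, para to a large group, read higher than hydrogen. No measurement given here accounts for this result.

Going by these compounds, it remains open whether a smaller group such as fluoro, or one carrying oxygen such as hydroxyl or methoxy, would stay nearer to compound 2 or match compound 1 and compound 3. The compounds shown also leave open how a larger group, such as an ethyl or a phenyl, would read at this carbon, and how methyl would read on the other carbons of this ring.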